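Benzyl chlorine shift from compound 3 to compound 4

The source may report more compounds than this note shows. Statements on the series, on what has been measured and on what is new or still open speak of the compounds shown alone.

Compound 1 `NC(=O)c1c(NC(=O)c2ccccc2Cl)sc2c1CCN(Cc1ccc(Cl)cc1Cl)C2`: 21100 nM
Compound 2 `NC(=O)c1c(NC(=O)c2ccc(C(F)(F)F)cc2)sc2c1CCN(Cc1ccc(Cl)cc1Cl)C2`: > 50000 nM (a limit, not a number)
Compound 3 `Cc1ccc(C(=O)Nc2sc3c(c2C(N)=O)CCN(Cc2c(Cl)cccc2Cl)C3)cc1`: 47400 nM

In a functional assay on HeLa cells (Homo sapiens) for antiproliferative activity, with a stated time of 24 h (a lower number here means a stronger inhibitor, a higher number a weaker inhibitor), compound 3 gives 47400 nM, the higher of the two actual numbers. Compound 1 is the nearest at 21100 nM, a gap beyond the scatter.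

Compound 4 `Cc1ccc(C(=O)Nc2sc3c(c2C(N)=O)CCN(Cc2ccc(Cl)cc2Cl)C3)cc1` differs from compound 3 only in the benzyl group: 2,4-dichlorophenyl in place of 2,6-dichlorophenyl on a saturated chain carbon bound to an amine nitrogen in a ring. It keeps the carbonyl side of compound 3 and takes the 2,4-dichlorobenzyl group of compound 1 and compound 2.

Among the measured compounds shown here, no measured step changes this group. For the measured compounds named here, the only step, an at least 2.3-fold higher number from compound 1 to compound 2 (0.37 log units; beyond the scatter), changes the group on the carbonyl, so it bears on the question only indirectly: with 2,4-dichlorobenzyl in place, the number still moves with the carbonyl side. A slight lean toward a lower number rests on compound 1 at 21100 nM, which carries the 2,4-dichlorobenzyl group. No step beyond the scatter is expected, and the estimated change is a 1.4-fold lower number from compound 3 to compound 4 (0.13 log units; within the scatter). For compound 4 the estimate is 35000 nM, with an expected range of 14000 nM to 65000 nM.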

Compound 4, half-maximal inhibitory concentration: > 50000 nM
Compound 4: no number, only a limit; the forecaster's own chance of this, stated with the estimate: 30%; at least 1.4-fold (0.15 log units) between middle value and limit.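

The benzyl position now has its first measured step in this assay and it is an at least 1.0-fold higher number from compound 3 to compound 4 (0.02 log units; that floor lies within the scatter) with the 4-methylphenyl carbonyl side held fixed, so the change from 2,6-dichlorobenzyl to 2,4-dichlorobenzyl shows no gain in potency here, while its true size stays unresolved. With 2,4-dichlorobenzyl in place, the carbonyl side now has a second readable step, an at least 2.3-fold higher number from compound 1 to compound 4 (0.37 log units; beyond the scatter) and this places 4-methylphenyl, like 4-(trifluoromethyl)phenyl, on the weaker side of 2-chlorophenyl, although the step between compound 2 and compound 4 cannot be read. Among the 2,4-dichlorobenzyl compounds only compound 1 has a number, so how far the other two lie from it or from each other cannot be resolved, because both stop at the assay limit: the limit of > 50000 nM in this assay, at which 2 of the 4 values shown sit.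

On these data alone, whether the benzyl change has a readable effect when the carbonyl carries 2-chlorophenyl stays open. Also open, as far as these compounds go, is how an amine or a carboxylic acid on the benzyl ring, or a longer chain in place of the benzyl link, would move the number.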